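The source may report more compounds than this note shows. Statements on the series, on what has been measured and on what is new or still open speak of the compounds shown alone.

Of the compounds shown here, three of a shared core have been measured in a functional assay on the whole organism with Rattus norvegicus as the target; a higher number here means that more compound is needed for the effect, a lower number that less compound is needed. Compound 1 `CCCCCCc1ccc2nc(N)sc2c1` gives 7 mg/kg in this assay. Compound 2 `Nc1nc2ccc(C(F)(F)C(F)(F)F)cc2s1` gives 2.5 mg/kg in this assay. Compound 3 `Cn1c(=N)sc2cc(OC(F)(F)F)ccc21` gives 5 mg/kg in this assay. On these three numbers compound 3 stands second highest, with compound 1 as its nearest neighbour and compound 2 as its furthest; both of those gaps fall within the usual scatter of repeated measurements, so no order among the three can be read from them.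

Compound 4 `CCCSCCn1c(=N)sc2cc(OC(F)(F)F)ccc21` differs from compound 3 in one place: (propylsulfanyl)methyl in place of hydrogen on a saturated chain carbon bound to an aromatic nitrogen. Going by the values given here, no measured pair of compounds shows a step of this kind, so there is no direct guide to its size. With nothing in the measured compounds pointing one way or the other, the step from compound 3 to compound 4 in this assay is expected to stay within the scatter, near a 1.2-fold higher number from compound 3 to compound 4 (0.08 log units; within the scatter). The value for compound 4 in this assay is therefore estimated at 6 mg/kg, with a range from 2.5 mg/kg to 15 mg/kg.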

Compound 4, dose for half-maximal effect: 2.4 mg/kg
For compound 4 the middle estimate is 2.5-fold (0.40 log units) above the measured one; measured number below the stated range.
By their numbers in this assay, from the lowest: compounds 4, 2, 3 and 1 (each within the scatter of the next, the first and the last beyond it).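

In this assay, the saturated chain carbon bound to an aromatic nitrogen accepts a much larger substituent without any loss: (propylsulfanyl)methyl in place of hydrogen gives a 2.1-fold lower number from compound 3 to compound 4 (0.32 log units; beyond the scatter), a modest gain. Going by these compounds alone, the earlier compounds offered no pair differing in one place, so this is the first evidence that changing this position can shift the dose needed, and that the shift can favour the longer chain. No evidence here explains the step.

The compounds shown cannot separate a contribution from the sulfur from one made by chain length alone, and an ether oxygen in place of the sulfur or an all-carbon chain would bear on that question. On these data alone, how a chain ending in an amine or a carboxylic acid would fare at this position also remains open.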